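The compounds below may be only part of what the source reports. "The series", "measured", "known", "first", "only" and "open" are said of these compounds alone.

Measured compounds in a functional assay on HL60/MX2 cells (Homo sapiens) for antiproliferative activity, read by MTT assay, with a stated time of 48 h; on this read-out higher numbers stand for weaker inhibition and lower numbers for stronger inhibition:

compound 1, `CN(C)CCn1c(N)c(-c2nc3ccccc3[nH]2)c2nc(C#N)c(C#N)nc21`, gives 3780 nM
compound 2, `CCN(CC)CCn1c(N)c(-c2nc3ccccc3[nH]2)c2nc(C#N)c(C#N)nc21`, gives 7150 nM
compound 3, `CN(C)CCCn1c(N)c(-c2nc3ccccc3n2C)c2nc(C#N)c(C#N)nc21`, gives 11300 nM

Compound 4, `CCN(CC)CCCn1c(N)c(-c2nc3ccccc3n2C)c2nc(C#N)c(C#N)nc21`, has not yet been measured in this assay.

Compound 1 and compound 2 share one core and differ in a single place: diethylamino in place of dimethylamino on a saturated chain carbon, two bonds along the chain from an aromatic nitrogen. In this assay that single change gave a 1.9-fold higher number from compound 1 to compound 2 (0.28 log units; within the scatter). Compound 3 and compound 4 share a second core; how the core of compound 3 differs from the core of compound 1 is not broken down here, and the two values of compound 1 and compound 3 show a gap beyond the scatter, with compound 3 the higher number. Compound 2 and compound 3 lie within the scatter of each other.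

Compound 4 differs from compound 3 by diethylamino in place of dimethylamino on a saturated chain carbon, three bonds along the chain from an aromatic nitrogen. For the measured compounds named here, this is the same kind of change as the one from compound 1 to compound 2, not the same change: there the place is two bonds along the chain from an aromatic nitrogen, here it is three bonds along the chain from an aromatic nitrogen. Going by the values given here, only one measured instance of the change exists, so the expectation rests on that single step and on the value of compound 3. Among the compounds with values here, the step from compound 3 to compound 4 in this assay is expected to be a 1.5-fold higher number from compound 3 to compound 4 (0.18 log units; within the scatter) because the one measured instance read a 1.9-fold higher number from compound 1 to compound 2 (0.28 log units; within the scatter). Compound 4 is accordingly expected to give 17000 nM, with a range from 8000 nM to 40000 nM.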

Compound 4, half-maximal inhibitory concentration: 4470 nM
Beside the measured number, compound 4's estimate is 3.8-fold (0.58 log units) above it; measured number outside the range, below it.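

In this assay, diethylamino in place of dimethylamino on a saturated chain carbon, three bonds along the chain from an aromatic nitrogen, gave a 2.5-fold lower number from compound 3 to compound 4 (0.40 log units; beyond the scatter), so the result on the core of compound 1 did not carry over to this second core: the same change on two cores in this assay, a 1.9-fold higher number (0.28 log units; within the scatter) from compound 1 to compound 2 and a 2.5-fold lower number (0.40 log units; beyond the scatter) from compound 3 to compound 4, 4.8-fold (0.68 log units) apart, beyond the scatter of two such steps Within these two pairs, the change therefore cannot be treated as a fixed increment to be added to any core in the series. This does not show which structural difference between the two pairs separates the steps, and each step rests on a single pair of compounds, with the earlier one within the scatter and thus not a clear change on its own.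

The compounds shown leave open whether the difference follows the chain or the rest of the core, since 2-(dimethylamino)ethyl and 2-(diethylamino)ethyl appear only with the core of compound 1, while 3-(dimethylamino)propyl and 3-(diethylamino)propyl appear only with the core of compound 3. Also open, as far as these compounds go, is how a dipropylamino group or a longer chain between the aromatic nitrogen and the amine would read on either core.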